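Ring in place of chain on the aryl ether oxygen

A few compounds are considered here, and "the series" means these few. Any claim that something is new, unique, unknown or untested is made for them only; others in the source may bear on it.

The series shares one core and varies the group on the aromatic oxygen. Compound 1 `CCOCCOc1cccc2ccc(N)nc12` carries ethoxy two bonds along the chain; compound 2 `CCCCCOc1cccc2ccc(N)nc12` carries pentyl; compound 3 `COC(C)(C)CCOc1cccc2ccc(N)nc12` carries 1-methoxy-1-methylethyl at that chain position. In an assay on cells with melanin-concentrating hormone receptor 1 (Homo sapiens) as the target, read by radioligand binding (a lower number here means a stronger inhibitor, a higher number a weaker inhibitor), compound 1 reaches only the assay limit, > 2000 nM. In this assay compound 2 gives 580 nM, the highest of the two numbers shown, and compound 3 gives 132 nM. The steps of an at least 3.4-fold lower number from compound 1 to compound 2 (0.53 log units; beyond the scatter), an at least 15-fold lower number from compound 1 to compound 3 (1.18 log units; beyond the scatter) and a 4.4-fold lower number from compound 2 to compound 3 (0.64 log units; beyond the scatter) show that this part of the molecule matters, with the latter being the limit of > 2000 nM in this assay, at which 1 of the 3 values shown sits -bounded only for compound 1.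

Compound 4 `CC1CCC(Oc2cccc3ccc(N)nc23)C1` is not yet measured. It differs from compound 2 by 3-methylcyclopentyl in place of pentyl on an oxygen on an aromatic ring. Within the data shown here, no measured step exchanges an open chain for a ring, so the expectation rests on the general sensitivity seen in a 4.4-fold lower number from compound 2 to compound 3 (0.64 log units; beyond the scatter) and is kept modest. Compound 4 is expected to give 400 nM, within 130 nM to 1200 nM, an estimated step of a 1.5-fold lower number from compound 2 to compound 4 (0.16 log units; within the scatter).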

Compound 4, half-maximal inhibitory concentration: 823 nM
Estimate against measurement, compound 4: 2.1-fold (0.31 log units) below; the range from low to high includes it.
By their numbers in this assay, from the lowest: compound 3; then compounds 2 and 4 (each within the scatter of the next). At a limit, above all of these: compound 1.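

In this assay, exchanging an open chain for a ring on the oxygen on an aromatic ring gives a 1.4-fold higher number from compound 2 to compound 4 (0.15 log units; within the scatter), so at this position 3-methylcyclopentyl and pentyl cannot be told apart. The ring also gives an at least 2.4-fold lower number from compound 1 to compound 4 (0.38 log units; beyond the scatter), which extends to a ring the separation that pentyl already showed from the 2-ethoxyethyl group of compound 1. This step has a bound on one side only, as the value for compound 1 is a limit: the limit of > 2000 nM in this assay, at which 1 of the 4 values shown sits.

The compounds shown leave open whether a ring carrying an ether oxygen or an amine would approach compound 3, at 132 nM. They also leave open how a plain cyclopentyl or a cyclohexyl group would compare with 3-methylcyclopentyl, and so what the methyl and the ring size each contribute.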